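The source may hold more compounds than are shown below. What is called first, only, known or untested is meant among the compounds shown, and "the series" means these compounds.

Compound 1 `COc1cc(C)cc(-c2c(-c3ccnc(-c4ccc(C(C)=O)cc4)c3)cnn2CC#N)c1` and compound 2 `Cc1cc(O)cc(-c2nn(CC#N)cc2-c2ccnc(-c3ccc(N(C)C)cc3)c2)c1` were both tested in a functional assay on SF-539 cells (Homo sapiens) for cytotoxicity, read by sulforhodamine B assay, with a stated time of 48 h, tested at 1 uM; on this read-out lower numbers stand for a stronger effect and higher numbers for a weaker effect at the one concentration tested. Compound 1 gives -45%, the lowest of the two numbers, while compound 2 gives -34%, a number higher by more than the usual scatter. Compound 3 `COc1cc(C)cc(-c2c(-c3ccnc(-c4ccc(N(C)C)cc4)c3)cnn2CC#N)c1` has not yet been measured; it differs from compound 1 in one place: dimethylamino in place of acetyl on an aromatic carbon. Among the measured compounds shown here, no measured pair isolates this change. A shift toward a weaker effect is expected because compound 2 also carries the dimethylamino group and gives -34%. The expected step of a number 7 percentage points higher from compound 1 to compound 3 (within the scatter) is small, probably within the scatter. Compound 3 is estimated at -38%, between -58% and -18%.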

Compound 3, a percentage reported as activity, at one concentration (the size of the read-out at that concentration, not a potency): 1%
Compound 3: the middle estimate sits 39 percentage points below what was measured; measured number above the stated range.
By their numbers in this assay, from the lowest: compound 1; then compound 2; then compound 3.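

In this assay, among the compounds shown here, the swap of acetyl for dimethylamino on this aromatic carbon, para to a large group, gives a number 46 percentage points higher from compound 1 to compound 3 (beyond the scatter) and is the first measured pair to isolate a change at this place. The read-out therefore depends strongly on this position, even though both groups count 3 heavy atoms and 1 hydrogen-bond acceptor. Nothing available here accounts for a step of this size.

Going by these compounds, it remains open how a carboxylic acid or a primary amine would read at this place. On these data alone, it therefore also remains open whether the step follows the loss of acetyl or the arrival of dimethylamino.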